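This account rests on a few compounds, and the source may have more. Where it says the series, first, only, none or still open, it means among the compounds named here.

Series notes. Compound 1 `CCOC(=O)C12C(=O)OCC=C1COC2c1ccccc1` carries no chloro on its aromatic ring. In a functional assay on QGY cells (Homo sapiens) for cytotoxicity, read by MTT assay (a lower number here means a stronger inhibitor, a higher number a weaker inhibitor), compound 1 gives only a limit, > 1000000 nM. Compound 2 `CCOC(=O)C12C(=O)OCC=C1COC2c1cccc(Cl)c1` and compound 3 `CCOC(=O)C12C(=O)OCC=C1COC2c1ccc(Cl)cc1` each carry one chloro on that ring. In this assay compound 2 likewise gives only a limit, > 1000000 nM. In this assay compound 3 also gives only a limit, > 1000000 nM. All three values sit at the limit of > 1000000 nM in this assay, at which 3 of the 3 values shown sit, so the steps a step that the two limits leave unreadable from compound 1 to compound 2, a step that the two limits leave unreadable from compound 1 to compound 3 and a step that the two limits leave unreadable from compound 2 to compound 3 cannot be sized. Compound 3 thus stands nowhere readable: it is one of three compounds at the limit.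

Compound 4 `CCOC(=O)C12C(=O)OCC=C1COC2c1ccc(Cl)c(Cl)c1` differs from compound 3 by chloro in place of hydrogen on an aromatic carbon. The measured steps that bear on this change, a step that the two limits leave unreadable from compound 1 to compound 2 and a step that the two limits leave unreadable from compound 1 to compound 3, each add a chloro to the aromatic ring, and neither is readable, since the limit of > 1000000 nM in this assay, at which 3 of the 3 values shown sit, holds every value shown. No step beyond the scatter in this assay is expected; the estimated step is a number no higher from compound 3 to compound 4 (the limit leaves the size open). Compound 4 is therefore expected at 1000000 nM, within 300000 nM to 3000000 nM, most probably again reported only as a limit.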

Compound 4, half-maximal inhibitory concentration: > 1000000 nM
Compound 4 gave a limit, no number (the forecaster's own chance of this, stated with the estimate: 85%); the middle value sits exactly at the limit.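

In this assay compound 4 gives only a limit, > 1000000 nM. Neither the step to compound 4 from compound 2 nor that from compound 3 can be read: the limit of > 1000000 nM in this assay, at which 4 of the 4 values shown sit.

The compounds shown leave open whether a chloro on the aromatic ring changes the result in this assay at all, and how far each compound lies beyond the limit.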